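This account rests on a few compounds, and the source may have more. Where it says the series, first, only, none or still open, it means among the compounds named here.

In a functional assay on CNE-2 cells (Homo sapiens) for inhibition, read by MTT assay, with a stated time of 72 h (a lower number here means a stronger inhibitor, a higher number a weaker inhibitor), compound 1 (`Nc1ncnc2c1c(-c1cnc3[nH]ccc3c1)nn2CC(=O)NO`) gives > 150000 nM as a limit. Compound 3 (`Nc1ncnc2c1c(-c1cnc3[nH]ccc3c1)nn2CCCCC(=O)NO`) gives > 150000 nM as a limit too. Compound 2 (`Nc1nc2cc(-c3nn(CCCC(=O)NO)c4ncnc(N)c34)ccc2o1`) gives > 50000 nM as a limit as well, so it stands without a number, like the other two. Compound 4 (`CNC(=O)CCCCCCCn1nc(-c2ccc3oc(N)nc3c2)c2c(N)ncnc21`) departs from it (4-(methylcarbamoyl)butyl in place of hydroxycarbamoyl on a saturated chain carbon, three bonds along the chain from an aromatic nitrogen) with 4-(methylcarbamoyl)butyl in place of hydroxycarbamoyl on a saturated chain carbon, three bonds along the chain from an aromatic nitrogen. Among the compounds with values here, the only measured step that bears on this is (a step that the two limits leave unreadable from compound 1 to compound 3), and its size cannot be read, so it gives no direction. In this assay the step (a step that the limit leaves unreadable from compound 2 to compound 4) is therefore expected to stay within the scatter. For compound 4 the estimated value is 70000 nM with an expected range (20000 nM to 200000 nM) around it.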

Compound 4, half-maximal inhibitory concentration: 2250 nM
For compound 4 the middle estimate is 31-fold (1.49 log units) above the measured one, outside the stated range (below it).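

In this assay, 4-(methylcarbamoyl)butyl in place of hydroxycarbamoyl on a saturated chain carbon, three bonds along the chain from an aromatic nitrogen, gives an at least 22-fold lower number from compound 2 to compound 4 (1.34 log units; beyond the scatter). Within the data shown here, the earlier step cannot be read, so this is the first sign that the group carried at this position can move the number. Its size is only a bound, because compound 2 stands at a limit: the limit of > 50000 nM in this assay, at which 1 of the 4 values shown sits.

As far as these compounds go, the longer chain and the methylcarbamoyl end change together, so which of them carries the step stays open. From the compounds shown here alone, how a carboxylic acid or an amine at the end of the same chain would read also stays open.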